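A Benzyl Group Joins the Aminomethyl Substituent

The source may hold more compounds than are shown below. What is called first, only, known or untested is meant among the compounds shown, and "the series" means these compounds.

Within the data shown here, compound 3 `COc1cc(Nc2nc(CN)cc3c(-c4ccccc4)n[nH]c23)cc(OC)c1OC` gives 132 nM in an assay on Flp-In-CHO cells for binding affinity to adenosine receptor A3 (Homo sapiens), read by NanoBRET (a lower number here means a stronger inhibitor, a higher number a weaker inhibitor), the highest of the three numbers measured so far. Its nearest neighbour is compound 2 `COc1cc(Nc2nccc3c(-c4ccccc4)n[nH]c23)cc(OC)c1OC`, which gives 100 nM, a step of a 1.3-fold higher number from compound 2 to compound 3 (0.12 log units; within the scatter). Compound 1 `COc1cc(Nc2nc(Cl)cc3c(-c4ccccc4)n[nH]c23)cc(OC)c1OC` gives 55 nM, and the step of a 2.4-fold higher number from compound 1 to compound 3 (0.38 log units; beyond the scatter) is modest. The unmeasured compound 4 `COc1cc(Nc2nc(CNCc3ccccc3)cc3c(-c4ccccc4)n[nH]c23)cc(OC)c1OC` differs from compound 3 in one place: benzyl in place of hydrogen on an amine nitrogen. Among the measured compounds shown here, no measured step touches this amine nitrogen; the steps of a 2.4-fold higher number from compound 1 to compound 3 (0.38 log units; beyond the scatter) and a 1.3-fold higher number from compound 2 to compound 3 (0.12 log units; within the scatter) only exchange the group on the aromatic carbon, and a 1.8-fold higher number from compound 1 to compound 2 (0.26 log units; within the scatter) swaps chloro for hydrogen there. Together they show that changes in this part of the shared core have moved the number only by small amounts. Nothing comparable to a benzyl on the amine has been tested, so the expectation rests on that narrow spread. Compound 4 is therefore expected to give 150 nM, with a range of 50 nM to 450 nM. The expected step is a 1.1-fold higher number from compound 3 to compound 4 (0.06 log units; within the scatter).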

Compound 4, inhibition constant: 85.1 nM
Estimate against measurement, compound 4: 1.8-fold (0.25 log units) above; measured number inside the range.
By their numbers in this assay, from the lowest: compounds 1, 4, 2 and 3 (each within the scatter of the next, the first and the last beyond it).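

Benzyl on the amine nitrogen is the first change at this atom, and it gives a 1.6-fold lower number from compound 3 to compound 4 (0.19 log units; within the scatter) in this assay, so a group with seven carbon atoms and an aromatic ring can stand here without moving the number beyond the scatter. Taken as a whole on the aromatic carbon, (benzylamino)methyl gives a 1.2-fold lower number from compound 2 to compound 4 (0.07 log units; within the scatter) in place of hydrogen and a 1.5-fold higher number from compound 1 to compound 4 (0.19 log units; within the scatter) in place of chloro, whereas aminomethyl in place of chloro gave a 2.4-fold higher number from compound 1 to compound 3 (0.38 log units; beyond the scatter). Nothing at hand explains this result.

The compounds shown leave open whether the aromatic ring of the benzyl matters at all, which a methyl or a cyclohexylmethyl on the same nitrogen would test, and whether a longer chain such as phenethyl behaves alike. They also leave open what a second group on that nitrogen, giving a tertiary amine, would do.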